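A few compounds are considered here, and "the series" means these few. Any claim that something is new, unique, unknown or untested is made for them only; others in the source may bear on it.

Measured compounds:
compound 1, `COc1ccc(C2C(C#N)=C(N)N(c3ccc(S(N)(=O)=O)cc3)C3=C2C(=O)CCC3)cc1`, in a functional assay on Ehrlich cells (Mus musculus) for antiproliferative activity, read by trypan blue exclusion, with a stated time of 2 h, tested at 25 ug/mL (a higher number here means a stronger effect of the compound at the concentration tested, a lower number a weaker effect), gives 50%
compound 2, `N#CC1=C(N)N(c2ccc(S(N)(=O)=O)cc2)C2=C(C(=O)CCC2)C1c1cccc([N+](=O)[O-])c1`, in this assay gives 50%

Compound 2 stands level with compound 1 at the digits shown; the step of no change at the digits printed from compound 1 to compound 2 (within the scatter) lies within the scatter of this assay, so the two values cannot be told apart. Compound 3, `N#CC1=C(N)N(c2ccc(S(N)(=O)=O)cc2)C2=C(C(=O)CCC2)C1c1ccc([N+](=O)[O-])cc1`, is the compound not yet measured. It differs from compound 2 in one place: 4-nitrophenyl in place of 3-nitrophenyl on a saturated ring carbon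

For the measured compounds named here, only one measured step bears on this change, the one from compound 1 to compound 2, where a 3-nitrophenyl group replaced a 4-methoxyphenyl group on the same saturated ring carbon and the read-out did not move beyond the scatter. That step exchanged one whole aryl group for another at the position now in question; the move from 3-nitrophenyl to 4-nitrophenyl keeps the same atoms and only rearranges them. On this single comparison no step beyond the scatter is expected for compound 3 in this assay.

Compound 3 is therefore estimated at 50%, with a range from 35% to 65%. The step this estimate implies, no change at the digits printed from compound 2 to compound 3 (within the scatter), is expected to stay within the scatter.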

Compound 3, a percentage reported as activity, at one concentration (the size of the read-out at that concentration, not a potency): 80%
The estimate for compound 3 lay 30 percentage points below the measured number; measured number above the stated range.
By their numbers in this assay, from the lowest: compounds 1 and 2 (each within the scatter of the next); then compound 3.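

In this assay, the saturated ring carbon proved sensitive not only to which aryl group it carries but also to how that group is arranged: 4-nitrophenyl in place of 3-nitrophenyl gives a number 30 percentage points higher from compound 2 to compound 3 (beyond the scatter), although the two groups hold the same atoms. Nitro in place of methoxy, with the group kept in the same arrangement on the aromatic carbon, gives a number 30 percentage points higher from compound 1 to compound 3 (beyond the scatter), so the exchange of these two groups can matter, which the level pair of compound 1 and compound 2 had not shown. No measurement at hand speaks to what lies behind this rise.

On these data alone, it remains open whether the higher read-out of compound 3 depends on the nitro group itself, or whether a carboxylic acid, an amine or a halogen such as chlorine in its place on the phenyl ring would hold it. The read-out also comes from one concentration and one stated time, so it leaves open how compound 3 would compare with compound 2 at other concentrations or over a full concentration range.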